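Working notes: cyano in place of chloro

The source may hold more compounds than are shown below. What is called first, only, known or untested is meant among the compounds shown, and "the series" means these compounds.

- compound 1 `Cc1cc(CCC(=O)O)ccc1-c1noc(-c2ccc(OC(C)C)c(C(F)(F)F)c2)n1`: 88%
- compound 2 `Cc1cc(CCC(=O)O)ccc1-c1noc(-c2ccc(OC(C)C)c(Cl)c2)n1`: 80%

In an in vivo ADME assay on the whole organism (strain Sprague-Dawley) for pharmacokinetics, with Rattus norvegicus as the target (a lower number here means that a smaller share of the oral dose reaches the circulation, a higher number that a larger share of the oral dose reaches the circulation), compound 2 gives 80%, within the scatter of compound 1 at 88%. Compound 3 `Cc1cc(CCC(=O)O)ccc1-c1noc(-c2ccc(OC(C)C)c(C#N)c2)n1` differs from compound 2 as follows: cyano in place of chloro on an aromatic carbon. Within the data shown here, the one measured step at this carbon is a number 8 percentage points lower from compound 1 to compound 2 (within the scatter), and it stays within the scatter. Among the measured compounds shown here, no measured compound carries cyano, so this single step is weak guidance, and no change beyond the scatter is expected in this assay. The expected step is a number 6 percentage points lower from compound 2 to compound 3 (within the scatter). For compound 3 the estimate is 74% (expected range 52% to 92%).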

Compound 3, oral bioavailability: 53%
The estimate for compound 3 lay 21 percentage points above the measured number; the measured number falls inside the stated range.
By their numbers in this assay, from the lowest: compound 3; then compounds 2 and 1 (each within the scatter of the next).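

In this assay cyano on this aromatic carbon gives a number 27 percentage points lower from compound 2 to compound 3 (beyond the scatter) and also a number 35 percentage points lower from compound 1 to compound 3 (beyond the scatter) on the shared core. This position is therefore not indifferent to its substituent: chloro and trifluoromethyl stay within the scatter of each other, and cyano alone separates from both. Nothing available bears on the reason for this separation. As far as these compounds go, whether the loss belongs to cyano alone or also appears with a methoxy group, a fluorine atom or a primary amide on this carbon stays open.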